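Chloro to Hydrogen on a Fused Two-Ring Core

A few compounds are considered here, and "the series" means these few. Any claim that something is new, unique, unknown or untested is made for them only; others in the source may bear on it.

Compound 1 `ClCc1cccc(Cn2cnc3c(Cl)ncnc32)c1`: 10500 nM
Compound 2 `ClCc1ccc(Cn2cnc3nc(Cl)nc(Cl)c32)cc1`: > 100000 nM
Compound 3 `ClCc1cccc(Cn2cnc3c(Cl)nc(Cl)nc32)c1`: 5370 nM

Three compounds were tested in a functional assay on COLO 205 cells (Homo sapiens) for cytotoxicity, read by sulforhodamine B assay, with a stated time of 48 h; a higher number here means a weaker inhibitor of growth, a lower number a stronger inhibitor of growth. Compound 3 gives 5370 nM, and compound 1 gives 10500 nM. The two share a core and differ by hydrogen in place of chloro on an aromatic carbon. This change produced a 2.0-fold higher number from compound 3 to compound 1 (0.29 log units; within the scatter).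

Compound 2 was tested in this assay as well, and for compound 2 the assay reports only a limit, > 100000 nM. That value is the limit of > 100000 nM in this assay, at which 1 of the 3 values shown sits. The core of compound 2 and the core of compound 3 are built from the same atoms joined differently; the difference between the two cores is not broken down here.

Compound 4 `ClCc1ccc(Cn2cnc3ncnc(Cl)c32)cc1` has not yet been measured in this assay. It differs from compound 2 by hydrogen in place of chloro on an aromatic carbon, which is the same change as that from compound 3 to compound 1, at a place described in the same words.

What is known of compound 4 rests on two things. For the measured compounds named here, the one measured instance of this change was a 2.0-fold higher number from compound 3 to compound 1 (0.29 log units; within the scatter), so the step itself is expected to be small, and compound 4 is estimated to lie a number no higher from compound 2 to compound 4 (the limit leaves the size open). The starting point of that step, however, is a limit rather than a number, which leaves the expected value for compound 4 wide and weighted toward weak growth inhibition. Compound 4 is expected to give 100000 nM in this assay, with a likely range from 20000 nM to 300000 nM.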

Compound 4, concentration for total growth inhibition: 3800 nM
Compound 4: the middle estimate sits 26-fold (1.42 log units) above what was measured; the measured number lies below the stated range.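

In this assay, hydrogen in place of chloro on an aromatic carbon gave an at least 26-fold lower number from compound 2 to compound 4 (1.42 log units; beyond the scatter). The change therefore does not carry over as one fixed step from one core to the other, since its two instances in this series disagree: the same change on two cores in this assay, a 2.0-fold higher number (0.29 log units; within the scatter) from compound 3 to compound 1 and an at least 26-fold lower number (1.42 log units; beyond the scatter) from compound 2 to compound 4, at least 51-fold (1.71 log units) apart, beyond the scatter of two such steps. From the compounds shown here alone, compound 2 gives > 100000 nM, which is a limit of the assay and not a number, so the full size of this step stays unknown, and two instances do not show which feature of the cores goes with the difference: the limit of > 100000 nM in this assay, at which 1 of the 4 values shown sits.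

The compounds shown have only chloro or hydrogen at the changed carbon, so it remains open whether an amine, a methoxy group or a longer chain there would follow the step seen on the core of compound 1 or the one seen on the core of compound 4. Going by these compounds, it also remains open how the change would behave on further cores, and whether replacing the chloromethyl group with a hydroxymethyl group or an amine would alter either step.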